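This account rests on a few compounds, and the source may have more. Where it says the series, first, only, none or still open, it means among the compounds named here.

Going by the values given here, compound 2 `Cc1ccc(C)c(N2CCN(C(=O)c3oc(C)nc3-c3ccc(F)cc3)CC2)c1` gives 358 nM in a functional assay on HL-60 cells (Homo sapiens) for inhibition, read by MTT assay, with a stated time of 72 h (a higher number here means a weaker inhibitor, a lower number a stronger inhibitor), the only number in this set; compound 1 `Cc1ccc(C)c(N2CCN(C(=O)c3oc(C)nc3-c3ccc(Cl)cc3)CC2)c1` is recorded in this assay as "not active" (no number reported), with no figure attached. Compound 3 `Cc1nc(-c2ccc(F)cc2)c(C(=O)N2CCN(c3ccc(Cl)cc3)CC2)o1` awaits measurement. Its change from compound 2: 4-chlorophenyl in place of 2,5-dimethylphenyl on an amine nitrogen in a ring. Among the compounds with values here, no step between measured compounds is available to size this change. Starting from compound 2 at 358 nM, the step is expected to be modest and toward a weaker value, a 2.2-fold higher number from compound 2 to compound 3 (0.35 log units; beyond the scatter), with wide uncertainty. Compound 3 is estimated at 800 nM in this assay, within 250 nM to 4000 nM.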

Compound 3, half-maximal inhibitory concentration: "not active" (no number reported)
The entry for compound 3 holds no number; there is nothing to compare the estimate with.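

Going by these compounds alone, compound 3 carries no number, so no step from compound 2 can be read, and no measured evidence bears on this result. The compounds shown leave open how 4-chlorophenyl compares numerically with 2,5-dimethylphenyl on the ring amine nitrogen.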